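Swapping Trimethoxyphenyl for Fluoro-Hydroxyphenyl at the Hydrazone

This account rests on a few compounds, and the source may have more. Where it says the series, first, only, none or still open, it means among the compounds named here.

Going by the values given here, compound 2 `COc1cc(/C=N/NC(=O)Nc2ccc(Oc3ccnc(-c4nncn4CCN(C)C)c3)c(F)c2)cc(OC)c1OC` stands at the top of the two numbers measured so far: in a functional assay on U-87MG ATCC cells (Homo sapiens) for cytotoxicity, read by MTT assay, with a stated time of 72 h (a higher number here means a weaker inhibitor, a lower number a stronger inhibitor), compound 2 gives 22500 nM. Among the compounds with values here, its only neighbour, compound 1 `CN(C)CCn1cnnc1-c1cc(Oc2ccc(NC(=O)N/N=C/c3ccccc3)cc2F)ccn1`, gives 2250 nM in this assay, and the single measured step, a 10-fold higher number from compound 1 to compound 2 (1.00 log units; beyond the scatter), lies beyond the scatter. Compound 3 `CN(C)CCn1cnnc1-c1cc(Oc2ccc(NC(=O)N/N=C/c3ccc(O)c(F)c3)cc2F)ccn1` has not yet been measured. It differs from compound 2 in one place: 3-fluoro-4-hydroxyphenyl in place of 3,4,5-trimethoxyphenyl on a carbon with a double bond to nitrogen. Within the data shown here, the measured step bears on this change only in part: it shows that going from plain phenyl to 3,4,5-trimethoxyphenyl weakened inhibition, whereas the fluorine and hydroxyl now entering have no measured precedent. Leaving 3,4,5-trimethoxyphenyl behind is therefore expected to bring the number partway back toward compound 1, so a modest decrease is expected, a 5.0-fold lower number from compound 2 to compound 3 (0.70 log units; beyond the scatter). Compound 3 is estimated at 4500 nM, with a range from 1500 nM to 14000 nM.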

Compound 3, half-maximal inhibitory concentration: > 100000 nM
Compound 3: no number, only a limit (the forecaster's own chance of this, stated with the estimate: 5%); at least 22-fold (1.34 log units) between middle value and limit.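

In this assay compound 3 gives no number, only a limit of the assay: the limit of > 100000 nM in this assay, at which 1 of the 3 values shown sits.

The step, an at least 4.4-fold higher number from compound 2 to compound 3 (0.64 log units; beyond the scatter), shows that leaving 3,4,5-trimethoxyphenyl behind does not by itself bring the number back toward plain phenyl, since the smaller 3-fluoro-4-hydroxyphenyl group moves it further the same way. With an at least 44-fold higher number from compound 1 to compound 3 (1.64 log units; beyond the scatter), plain phenyl now holds the lowest of the three values, and both substituted rings shown on this carbon with a double bond to nitrogen weaken inhibition.

The fluorine and the hydroxyl enter together, so their separate shares in this loss cannot be told apart. A phenyl carrying only a hydroxyl or only a fluorine would separate them, and an amine on the ring would show whether any other substituent here is tolerated.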